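Swapping Ring Substituents: A Small Expected Step

The source may report more compounds than this note shows. Statements on the series, on what has been measured and on what is new or still open speak of the compounds shown alone.

Measured so far:
- compound 1, `Cc1ccc(S(=O)(=O)NC(=O)Nc2ccccc2C(=O)/C=C/c2ccccc2)cc1`, in an ADME assay on the whole organism for cytotoxicity, with Artemia salina as the target, with a stated time of 24 h (on this read-out lower numbers stand for an effect already at smaller amounts and higher numbers for an effect only at larger amounts of compound), gives 25 ug/mL
- compound 2, `COc1ccc(/C=C/C(=O)c2ccccc2NC(=O)NS(=O)(=O)c2ccc(C)cc2)cc1OC`, in this assay gives 12.9 ug/mL
- compound 3, `CCc1cc(/C=C/C(=O)c2ccccc2NC(=O)NS(=O)(=O)c2ccc(C)cc2)cc(OC)c1OC`, in this assay gives 19.2 ug/mL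

The three compounds share one core and differ only in the group on a double-bonded chain carbon bound to a double-bonded chain carbon. Compound 2 lies within the scatter of both others: a 1.9-fold lower number from compound 1 to compound 2 (0.29 log units; within the scatter), and a 1.5-fold higher number from compound 2 to compound 3 (0.17 log units; within the scatter). The remaining pair also stays close, with a 1.3-fold lower number from compound 1 to compound 3 (0.11 log units; within the scatter).

Compound 4, `CCOc1cc(/C=C/C(=O)c2ccccc2NC(=O)NS(=O)(=O)c2ccc(C)cc2)ccc1O`, has not yet been measured. It arises from compound 2 by 3-ethoxy-4-hydroxyphenyl in place of 3,4-dimethoxyphenyl on a double-bonded chain carbon bound to a double-bonded chain carbon. For the measured compounds named here, both measured steps that alter this same group, the one from compound 1 to compound 2 and the one from compound 2 to compound 3, were small and within the scatter, so a further change of the same group is expected to give no step beyond the scatter in this assay. Compound 4 is therefore estimated at 15 ug/mL, with a range from 7 ug/mL to 32 ug/mL. The expected step from compound 2 is a 1.2-fold higher number from compound 2 to compound 4 (0.07 log units; within the scatter).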

Compound 4, concentration for half-maximal effect: 19.2 ug/mL
Beside the measured number, compound 4's estimate is 1.3-fold (0.11 log units) below it, within the range that was stated.
By their numbers in this assay, from the lowest: compounds 2, 3, 4 and 1 (each within the scatter of the next).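

The 3-ethoxy-4-hydroxyphenyl group has 1 hydrogen-bond donor where 3,4-dimethoxyphenyl has 0, yet in this assay this rearrangement of the same atoms gives a 1.5-fold higher number from compound 2 to compound 4 (0.17 log units; within the scatter) and so adds no step beyond the scatter. The comparisons with the other two groups agree, with no change at the digits printed from compound 3 to compound 4 (within the scatter) and a 1.3-fold lower number from compound 1 to compound 4 (0.11 log units; within the scatter), so all four groups on a double-bonded chain carbon bound to a double-bonded chain carbon now stay within the scatter of one another. Nothing available explains why this position tolerates these changes.

Each group shown here is an aromatic ring of carbon only, bearing at most ethyl, methoxy, ethoxy or hydroxy, so a ring carrying an amine or a carboxylic acid remains untested in this set. Going by these compounds, whether such a group would move the number beyond the scatter stays open.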